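This account rests on a few compounds, and the source may have more. Where it says the series, first, only, none or still open, it means among the compounds named here.

Within the data shown here, compound 1 `C=CC[C@H]1C[C@]2([C@@H](C)Cc3ccc(OC)c(OC)c3)OCOC2=CC1=O` gives 260 nM in a functional assay on NCI-H460 cells (Homo sapiens) for antiproliferative activity, with a stated time of 72 h (a higher number here means a weaker inhibitor, a lower number a stronger inhibitor), the only plain number among the two values shown. Compound 2 `C=CC[C@@H]1C[C@]2([C@H](C)Cc3ccc(OC)c(OC)c3)OCOC2=CC1=O` gives > 4000 nM in this assay, which is a limit of the assay rather than a number. The step of an at least 15-fold higher number from compound 1 to compound 2 (1.18 log units; beyond the scatter) is tied to the fact that compounds 1 and 2 differ only in the configuration as drawn and to the limit of > 4000 nM in this assay, at which 1 of the 2 values shown sits. Compound 3 `C=CC[C@H]1C[C@]2([C@@H](C)Cc3ccc(OC)cc3)OCOC2=CC1=O` differs from compound 1 by hydrogen in place of methoxy on an aromatic carbon. Among the measured compounds shown here, no measured step removes a methoxy group, so the measured step offers no direct guide here. Compound 3 is therefore expected to show only a small step of a 1.9-fold higher number from compound 1 to compound 3 (0.28 log units; within the scatter), toward a higher number. The estimate for compound 3 is 500 nM, between 150 nM and 2500 nM.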

Compound 3, half-maximal inhibitory concentration: 90 nM
Compound 3: the middle estimate sits 5.6-fold (0.74 log units) above what was measured, and the stated range ends above it.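

The earlier pair differed only in configuration as drawn, whereas this change swaps atoms on the aromatic ring. Hydrogen in place of methoxy on this aromatic carbon gives a 2.9-fold lower number from compound 1 to compound 3 (0.46 log units; beyond the scatter) in this assay and so moves the number toward the stronger side, which shows that this methoxy group is not needed for activity here. Nothing measured here accounts for the shift. On these data alone, whether a hydroxyl, a fluorine or an amine on this carbon would lower the number further stays open. So does whether the remaining methoxy group could also give way to hydrogen.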